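Swapping Chlorophenyl for Methylimidazole on the Sulfonyl Group

A few compounds are considered here, and "the series" means these few. Any claim that something is new, unique, unknown or untested is made for them only; others in the source may bear on it.

Compound 1 `CC1CCN(C2CCN(S(=O)(=O)c3ccccc3Br)CC2)CC1` gives 3 nM in a functional assay on DLD-1 cells (Homo sapiens) for antiproliferative activity, read by CellTiter-Glo, with a stated time of 72 h; on this read-out lower numbers stand for stronger inhibition and higher numbers for weaker inhibition. Compound 2 `CC1CCN(C2CCN(S(=O)(=O)c3cccc(Cl)c3)CC2)CC1` gives > 5000 nM in this assay, which is a limit of the assay rather than a number. The step of an at least 1600-fold higher number from compound 1 to compound 2 (3.22 log units; beyond the scatter) is thus known only as a bound. Compound 3 `CC1CCN(C2CCN(S(=O)(=O)c3cn(C)cn3)CC2)CC1` differs from compound 2 by 1-methyl-1H-imidazol-4-yl in place of 3-chlorophenyl on a sulfonyl sulfur. Among the compounds with values here, no measured step covers this change; the single measured step was large and lost activity, and compound 2 already sits at the limit (the limit of > 5000 nM in this assay, at which 1 of the 2 values shown sits). Compound 3 is therefore expected to stay near that limit, with the step that the limit leaves unreadable from compound 2 to compound 3 expected to be small, giving an estimate of 6000 nM (range 1000 nM to 30000 nM).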

Compound 3, half-maximal inhibitory concentration: > 5000 nM
Compound 3 ended at the assay's limit; the forecaster's own chance of this, stated with the estimate: 65%; the middle value does not contradict the limit.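

Compound 3 shows that the loss of activity on the sulfonyl sulfur is not confined to 3-chlorophenyl: with 1-methyl-1H-imidazol-4-yl, this assay also records an at least 1600-fold higher number from compound 1 to compound 3 (3.22 log units; beyond the scatter). So far, 2-bromophenyl is the only group shown that gives strong inhibition. The step between compound 2 and compound 3 cannot be read, since both sit at the same assay limit and not at a number: the limit of > 5000 nM in this assay, at which 2 of the 3 values shown sit.

As far as these compounds go, whether a plain phenyl group or a pyridine ring on the sulfonyl sulfur would keep any activity remains open. Also open, from the compounds shown here alone, is which feature of 2-bromophenyl matters for the activity of compound 1.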